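Pyridin-3-yl to 4-Methoxyphenyl: Expected Potency of Compound 4

The source may hold more compounds than are shown below. What is called first, only, known or untested is meant among the compounds shown, and "the series" means these compounds.

Measured so far:
Compound 1, `COc1ccc(S(=O)(=O)N2CCc3cccc(-c4cccnc4)c32)cc1`, gives 68.5 nM in a functional assay on MKN-45 cells (Homo sapiens) for inhibition, with a stated time of 72 h; on this read-out lower numbers stand for stronger inhibition and higher numbers for weaker inhibition.
Compound 2, `COc1ccc(S(=O)(=O)N2CCc3cccc(-c4ccc(F)cc4)c32)cc1`, gives 79 nM.
Compound 3, `COc1ccc(S(=O)(=O)N2CCc3cccc(-c4ccc(F)nc4)c32)cc1`, gives 145 nM.

Compound 1 holds the lowest number of the three; compound 2 sits within the scatter of it, whereas compound 3 lies beyond it, as a 2.1-fold higher number from compound 1 to compound 3 (0.33 log units; beyond the scatter) shows. Compound 4, `COc1ccc(-c2cccc3c2N(S(=O)(=O)c2ccc(OC)cc2)CC3)cc1`, differs from compound 1 in one place: 4-methoxyphenyl in place of pyridin-3-yl on an aromatic carbon. The step that bears most on this change is a 1.2-fold higher number from compound 1 to compound 2 (0.06 log units; within the scatter), in which pyridin-3-yl likewise gave way to a carbon-only aromatic ring carrying one substituent, with no shift beyond the scatter. The modest loss in a 2.1-fold higher number from compound 1 to compound 3 (0.33 log units; beyond the scatter) concerns a fluoro added to the pyridine and is less telling. Compound 4 is therefore expected to give 90 nM, with a range of 35 nM to 250 nM. The expected step, a 1.3-fold higher number from compound 1 to compound 4 (0.12 log units; within the scatter), is estimated to remain within the scatter.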

Compound 4, half-maximal inhibitory concentration: 211 nM
The estimate for compound 4 lay 2.3-fold (0.37 log units) below the measured number; measured number inside the range.
By their numbers in this assay, from the lowest: compounds 1, 2, 3 and 4 (each within the scatter of the next, the first and the last beyond it).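

In this assay the group carried by the carbon-only ring now matters at this position: methoxy in place of fluoro gives a 2.7-fold higher number from compound 2 to compound 4 (0.43 log units; beyond the scatter) and 4-methoxyphenyl in place of pyridin-3-yl gives a 3.1-fold higher number from compound 1 to compound 4 (0.49 log units; beyond the scatter) while the earlier change to 4-fluorophenyl had stayed within the scatter. From 6-fluoropyridin-3-yl to 4-methoxyphenyl the step is a 1.5-fold higher number from compound 3 to compound 4 (0.16 log units; within the scatter) so those two groups are not separated here. Nothing shown gives a reason for these steps.

On these data alone, whether a methyl, an amine or a carboxylic acid on this ring would stay within the scatter of compound 1 remains open. So does whether methoxy on a pyridine ring would behave as it does on the carbon-only ring.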